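Ester Versus Amide on the Cyclohexyl Ring

The source may report more compounds than this note shows. Statements on the series, on what has been measured and on what is new or still open speak of the compounds shown alone.

Compound 1 `O=C(OC1CCC(CN2CCN(c3cc(=O)c4cc(C(F)(F)F)cc([N+](=O)[O-])c4s3)CC2)CC1)C1CCCCC1`: 0.0783 h
Compound 2 `CS(=O)(=O)NC1CCC(CN2CCN(c3cc(=O)c4cc(C(F)(F)F)cc([N+](=O)[O-])c4s3)CC2)CC1`: a limit, > 1.55 h
Compound 3 `CC(=O)NC1CCC(CN2CCN(c3cc(=O)c4cc(C(F)(F)F)cc([N+](=O)[O-])c4s3)CC2)CC1`: a limit, > 1.55 h

In an ADME assay on cells (Hepatocyte, Mus musculus) for metabolic stability (on this read-out higher numbers stand for a longer-lived compound and lower numbers for a shorter-lived compound), compound 1 gives 0.0783 h. For compound 2 this assay reports only a limit, > 1.55 h. For compound 3 this assay likewise reports only a limit, > 1.55 h. Compound 3 thus stands at the limit of > 1.55 h in this assay, at which 2 of the 3 values shown sit, and the step that the two limits leave unreadable from compound 2 to compound 3 cannot be read.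

Compound 4 `O=C(OC1CCC(CN2CCN(c3cc(=O)c4cc(C(F)(F)F)cc([N+](=O)[O-])c4s3)CC2)CC1)c1ccc(F)cc1` carries the change (((4-fluorophenyl)carbonyl)oxy in place of acetamido on a saturated ring carbon). Among the measured compounds shown here, two measured steps bear on it, both running in the opposite direction: an at least 19-fold higher number from compound 1 to compound 3 (1.29 log units; beyond the scatter) and an at least 19-fold higher number from compound 1 to compound 2 (1.29 log units; beyond the scatter). In each, an ester on the saturated ring carbon was exchanged for an amide, and the number in this assay rose by a large step. Compound 4 brings an ester back to that carbon, with a ((4-fluorophenyl)carbonyl)oxy group in place of acetamido, so a large fall from compound 3 is expected, an at least 10-fold lower number from compound 3 to compound 4 (1.01 log units; beyond the scatter). Compound 4 is therefore estimated at 0.15 h, within a range from 0.05 h to 0.6 h.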

Compound 4, half-life: 0.0817 h
Estimate against measurement, compound 4: 1.8-fold (0.26 log units) above, and the stated range covers the measured number.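

In this assay, the ester stays short-lived when its acyl part changes from saturated to aromatic: placing 4-fluorophenyl on the carbonyl carbon gives a 1.0-fold higher number from compound 1 to compound 4 (0.02 log units; within the scatter). Against the nitrogen-linked groups on the same saturated ring carbon, the new ester repeats the large gap seen for compound 1, with an at least 18-fold lower number from compound 3 to compound 4 (1.27 log units; beyond the scatter) and an at least 18-fold lower number from compound 2 to compound 4 (1.27 log units; beyond the scatter), so among these four compounds the two esters fall together and the acetamido and methanesulfonamido compounds stand apart. Both of these new steps start from a limit of the assay rather than a number: the limit of > 1.55 h in this assay, at which 2 of the 4 values shown sit.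

The compounds shown leave open whether an ether or a carbamate on that saturated ring carbon would side with the esters or with the acetamido and methanesulfonamido compounds. From the compounds shown here alone, the step between those last two cannot be read, so their order also stays open.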